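The source may report more compounds than this note shows. Statements on the series, on what has been measured and on what is new or still open speak of the compounds shown alone.

Two compounds have been measured in a functional assay on PANC-1 cells (Homo sapiens) for cytotoxicity, read by WST assay, with a stated time of 24 h (a lower number here means a stronger inhibitor, a higher number a weaker inhibitor), so far:

- Compound 1 `O=C(/C=C/CCCCCCc1ccccc1)NCc1ccccc1` gives > 100000 nM
- Compound 2 `Cc1ccc(CCCCCCCCC(=O)N2CCCCC2)cc1` gives > 100000 nM

Both readings are limits and not numbers. Among the compounds with values here, compound 2 therefore has no exact place, and it shares its position with compound 1 at the limit of > 100000 nM in this assay, at which 2 of the 2 values shown sit, as the only evidence. Compound 3 `O=C(CCCCCCCCc1ccccc1Cl)N1CCCCC1` carries 2-chlorophenyl in place of 4-methylphenyl on a saturated chain carbon, eight bonds along the chain from a carbonyl carbon, and the count of that change is 2-chlorophenyl in place of 4-methylphenyl on a saturated chain carbon, eight bonds along the chain from a carbonyl carbon in full. Within the data shown here, no measured step exists to size this change. In this assay no shift beyond the scatter is expected, and the estimated change is an at least 1.2-fold lower number from compound 2 to compound 3 (0.09 log units; that floor lies within the scatter) at most a modest gain in strength. Another reading that is only a limit is quite likely. For compound 3 the estimate is 80000 nM with an expected range from 20000 nM to 200000 nM in this measurement.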

Compound 3, half-maximal inhibitory concentration: > 100000 nM
Compound 3: no number, only a limit; the forecaster's own chance of this, stated with the estimate: 65%; middle value at least 1.2-fold (0.09 log units) away from the limit.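

In this assay compound 3 gives > 100000 nM as a limit and not a number. Within the data shown here, compound 2 also stands at a limit, so no step between compound 2 and compound 3 can be read. The compounds shown leave open whether any of them has a measurable half-maximal inhibitory concentration here, since the only evidence is a shared ceiling: the limit of > 100000 nM in this assay, at which 3 of the 3 values shown sit.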